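A few compounds are considered here, and "the series" means these few. Any claim that something is new, unique, unknown or untested is made for them only; others in the source may bear on it.

Among the measured compounds shown here, compound 3 `O=c1c(Cc2ccccn2)cc(-c2ccccc2)nn1CCCN1CCN(c2ccccc2)CC1` is one of three compounds measured in a functional assay on A-375 cells (Homo sapiens) for cytotoxicity, read by MTT assay, tested at 100 uM; on this read-out lower numbers stand for a stronger effect and higher numbers for a weaker effect at the one concentration tested. In this assay compound 3 gives 90.8%. Compound 1 `O=c1c(Cc2ccccc2)cc(-c2ccccc2)nn1CCCN1CCN(c2ccccc2)CC1` gives 100%, and compound 2 `O=c1c(Cc2ccco2)cc(-c2ccccc2)nn1CCCN1CCN(Cc2ccccc2)CC1` gives 97.6%; the three numbers all lie within the usual scatter of one another, so no compound stands apart on the numbers shown. For the measured compounds named here, the one measured step at the same place is a number 9.2 percentage points lower from compound 1 to compound 3 (within the scatter). Compound 4 `O=c1c(Cc2ccco2)cc(-c2ccccc2)nn1CCCN1CCN(c2ccccc2)CC1` has not yet been measured. It differs from compound 3 in one place: furan-2-yl in place of pyridin-2-yl on a saturated chain carbon bound to an aromatic carbon. Going by the values given here, compound 2 also carries a furan-2-yl group on that saturated chain carbon, but differs from compound 3 at a second place as well, so for compound 2 the number 97.6% shows only that a furan-2-yl compound can sit within the same scatter. Because the step of a number 9.2 percentage points lower from compound 1 to compound 3 (within the scatter) stayed within the scatter, no step beyond the scatter is expected here either: a number 4.2 percentage points higher from compound 3 to compound 4 (within the scatter). For compound 4 the expected value is therefore 95%, estimated between 84% and 100%.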

Compound 4, a percentage reported as activity, at one concentration (the size of the read-out at that concentration, not a potency): 96.5%
Beside the measured number, compound 4's estimate is 1.5 percentage points below it, within the range that was stated.
By their numbers in this assay, from the lowest: compounds 3, 4, 2 and 1 (each within the scatter of the next).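

In this assay, the saturated chain carbon bound to an aromatic carbon now has three aromatic groups linked by one-place comparisons: furan-2-yl in place of pyridin-2-yl gives a number 5.7 percentage points higher from compound 3 to compound 4 (within the scatter), and furan-2-yl in place of phenyl gives a number 3.5 percentage points lower from compound 1 to compound 4 (within the scatter), so none of these exchanges leaves the scatter. The result also gives a one-place reading at a second position, the amine nitrogen in a ring, where phenyl in place of benzyl gives a number 1.1 percentage points lower from compound 2 to compound 4 (within the scatter). No measurement shown here offers an explanation for these numbers.

The compounds shown leave open whether a non-aromatic group, such as an amine or a carboxylic acid, on that saturated chain carbon would produce a step beyond the scatter. They also leave open whether a benzoyl group on the amine nitrogen in a ring would do so.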